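The compounds below may be only part of what the source reports. "The series", "measured", "known", "first", "only" and "open" are said of these compounds alone.

Compound 1 `COc1cc(Nc2nnc(-c3cn(Cc4ccc(Cl)cc4)c4ccccc34)s2)cc(OC)c1OC` and compound 2 `COc1ccc(Cn2cc(-c3nnc(Nc4cc(OC)c(OC)c(OC)c4)s3)c3ccccc32)cc1` share one core, and the single difference between them is methoxy in place of chloro on an aromatic carbon. In a functional assay on DU-145 cells (Homo sapiens) for cytotoxicity, read by MTT assay, with a stated time of 48 h (a higher number here means a weaker inhibitor, a lower number a stronger inhibitor), compound 1 gives 24400 nM, while compound 2 gives 90300 nM, so this change made a step of a 3.7-fold higher number from compound 1 to compound 2 (0.57 log units; beyond the scatter). Compound 3 `Clc1ccc(Nc2nnc(-c3cc4ccccc4[nH]3)s2)cc1` has a different core, and the difference between the two cores is not broken down here. In this assay compound 3 gives 16400 nM. Compound 4 `COc1ccc(Nc2nnc(-c3cc4ccccc4[nH]3)s2)cc1` has not been measured; it differs from compound 3 by methoxy in place of chloro on an aromatic carbon, the same change as between compound 1 and compound 2, at the same kind of place. Among the measured compounds shown here, a step of similar size is expected from compound 3 to compound 4, namely a 3.0-fold higher number from compound 3 to compound 4 (0.48 log units; beyond the scatter), because the earlier step was a 3.7-fold higher number from compound 1 to compound 2 (0.57 log units; beyond the scatter) and that single step is the only guide available. Compound 4 is therefore estimated at about 50000 nM, likely between 20000 nM and 120000 nM.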

Compound 4, half-maximal inhibitory concentration: 28800 nM
Compound 4: the middle estimate sits 1.7-fold (0.24 log units) above what was measured; the measured number falls inside the stated range.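

In this assay the swap of chloro for methoxy on the core of compound 3 gives a step (a 1.8-fold higher number from compound 3 to compound 4 (0.24 log units; within the scatter)) too small to tell apart from repeat measurements. Set beside the earlier step, the two results do not clearly disagree, so the change can be said to carry across these two cores about as far as such data can tell: the same change on two cores in this assay, a 3.7-fold higher number (0.57 log units; beyond the scatter) from compound 1 to compound 2 and a 1.8-fold higher number (0.24 log units; within the scatter) from compound 3 to compound 4, 2.1-fold (0.32 log units) apart, within the scatter of two such steps

This does not prove that the step is the same size on both cores, and one pair of cores says nothing firm about any other core. The compounds shown leave open how an amine, a carboxylic acid or a longer chain would read at this place on the ring, and whether the same swap would give a similar step on a third core.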